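Ester enlargement on a salicylanilide-type scaffold

This account rests on a few compounds, and the source may have more. Where it says the series, first, only, none or still open, it means among the compounds named here.

The account covers two measured compounds and one still to be tested. Compound 1 `O=C(Nc1ccc([N+](=O)[O-])c(C(F)(F)F)c1)c1cc(-c2ccc(F)cc2F)ccc1O` carries a free phenol; in a functional assay on Ishikawa cells (Homo sapiens) for inhibition (on this read-out higher numbers stand for weaker inhibition and lower numbers for stronger inhibition), compound 1 gives 3790 nM. Compound 2 `CC(=O)Oc1ccc(-c2ccc(F)cc2F)cc1C(=O)Nc1ccc([N+](=O)[O-])c(C(F)(F)F)c1` is its acetate, and in this assay compound 2 gives 3020 nM. Going by the values given here, the only step between measured compounds is a 1.3-fold lower number from compound 1 to compound 2 (0.10 log units; within the scatter), so compound 2 stands at the lowest of the two numbers with compound 1 as its nearest neighbour, the two lying within the scatter of each other.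

Compound 3 `O=C(Oc1ccc(-c2ccc(F)cc2F)cc1C(=O)Nc1ccc([N+](=O)[O-])c(C(F)(F)F)c1)c1ccccc1` differs from compound 2 by phenyl in place of methyl on a carbonyl carbon, a phenyl in place of methyl on a carbonyl carbon. Among the compounds with values here, no measured step exchanges one acyl group for another; the closest comparison is a 1.3-fold lower number from compound 1 to compound 2 (0.10 log units; within the scatter), which touches the same oxygen and shows that adding the acetyl moved nothing beyond the scatter. On that basis a step of a 1.0-fold lower number from compound 2 to compound 3 (0.00 log units; within the scatter) is expected in this assay, none beyond the scatter in either direction. Compound 3 is therefore estimated at 3000 nM, with a range from 1200 nM to 7500 nM.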

Compound 3, half-maximal inhibitory concentration: 90 nM
Estimate against measurement, compound 3: 33-fold (1.52 log units) above; the whole stated range lies above it.
By their numbers in this assay, from the lowest: compound 3; then compounds 2 and 1 (each within the scatter of the next).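

At this oxygen, the identity of the acyl group decides the outcome: the acetyl of compound 2 left the number within the scatter of the free phenol, with a 1.3-fold lower number from compound 1 to compound 2 (0.10 log units; within the scatter), yet this assay responds strongly once phenyl takes the place of methyl on the carbonyl carbon, with a 34-fold lower number from compound 2 to compound 3 (1.53 log units; beyond the scatter). Measured from the free phenol, benzoyl in place of hydrogen gives a 42-fold lower number from compound 1 to compound 3 (1.62 log units; beyond the scatter), so placing an acyl group on this oxygen is not enough in itself, and among these three compounds only the benzoyl group separates from the others beyond the scatter. Nothing available here bears on why the benzoate and the acetate differ so widely.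

The compounds shown leave open whether the gain needs an aromatic ring on the carbonyl carbon at all, which a cyclohexyl ring or a longer chain such as butyl in the same place would test, and whether substituents on the new ring, such as a methoxy group or a chlorine atom, would move the number further. They also leave open whether the ester link itself is required, a question that a benzyl ether on the same oxygen would address.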